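Removing the nitro group: what happens to cytotoxicity

The compounds below may be only part of what the source reports. "The series", "measured", "known", "first", "only" and "open" are said of these compounds alone.

Measured compounds:
compound 1, `C/C(=N\NC(=O)COc1cccc2ccccc12)c1ccc([N+](=O)[O-])cc1`, > 100 ug/mL
compound 2, `O=C(COc1cccc2ccccc12)N/N=C/c1ccccc1O`, 3.57 ug/mL

Of the compounds shown here, two sharing the same core have been tested in an ADME assay on HEL cells (Homo sapiens) for cytotoxicity; on this read-out lower numbers stand for higher toxicity in this test and higher numbers for lower toxicity in this test. In this assay compound 1 gives > 100 ug/mL, which is a limit of the assay rather than a measured number. Compound 1 therefore sits at the limit of > 100 ug/mL in this assay, at which 1 of the 2 values shown sits. Compound 2, in this assay, gives 3.57 ug/mL, a true number. Within the data shown here, no step between two measured compounds is available here, so the two values can only be read side by side.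

The unmeasured compound 3, `C/C(=N\NC(=O)COc1cccc2ccccc12)c1ccccc1`, differs from compound 1 by hydrogen in place of nitro on an aromatic carbon: the nitro group leaves and a hydrogen atom enters. For the step of an at least 1.2-fold lower number from compound 1 to compound 3 (0.09 log units; that floor lies within the scatter) an expected change of no more than the usual scatter, or a small move toward a lower number, seems most likely. For compound 3 the estimated value in this assay is 80 ug/mL, with a range from 20 ug/mL to 200 ug/mL.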

Compound 3, half-maximal cytotoxic concentration: 20 ug/mL
Compound 3: middle estimate off by 4.0-fold (0.60 log units), on the high side; low and high end bracket the measured number.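

In this assay, the change from 4-nitrophenyl to phenyl gives an at least 5.0-fold lower number from compound 1 to compound 3 (0.69 log units; beyond the scatter), so removing the nitro group goes with higher toxicity in this test, a link that the earlier side-by-side values could not show. Compound 1 gives > 100 ug/mL, which is a limit and not a number. The full size of the step therefore stays unknown and only its smallest possible size is fixed, because compound 1 stands at the edge of what the test reports: the limit of > 100 ug/mL in this assay, at which 1 of the 3 values shown sits.

The compounds shown leave open whether another group at this place on the ring, such as an amine or a carboxylic acid, would stay at the limit or come close to compound 3. Compound 2 differs from these compounds in more than one place, so it cannot settle this.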